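A chloro-to-iodo swap in a small antiproliferative series

The source may hold more compounds than are shown below. What is called first, only, known or untested is meant among the compounds shown, and "the series" means these compounds.

In a functional assay on MCF7 cells (Homo sapiens) for antiproliferative activity (a lower number here means a stronger inhibitor of growth, a higher number a weaker inhibitor of growth), compound 1 `COc1ccc(-c2nc3cc(F)ccc3s2)cc1` gives 490 nM. Compound 2 `COc1ccc(-c2nc3cc(F)ccc3s2)cc1Cl`, with chloro in place of hydrogen on an aromatic carbon, gives 760 nM, which places compound 2 within the scatter of compound 1, so the two cannot be ranked. The next structure is compound 3 `COc1ccc(-c2nc3cc(F)ccc3s2)cc1I`, which has iodo in place of chloro on an aromatic carbon. This carbon belongs to a six-membered aromatic ring of carbon only and is ortho to a methoxy group and meta to a large group. Within the data shown here, no measured compound carries iodo, so the data offer no direct guide to this substituent. Resting on a 1.6-fold higher number from compound 1 to compound 2 (0.19 log units; within the scatter), the only measured step that bears on this change and one at the same aromatic carbon, no shift beyond the scatter is expected in this assay. The expected step is a 1.1-fold higher number from compound 2 to compound 3 (0.02 log units; within the scatter), an estimate with no meaningful direction. For compound 3 the estimated value is 800 nM, with an expected range from 300 nM to 2000 nM.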

Compound 3, concentration for 50% growth inhibition: 820 nM
Beside the measured number, compound 3's estimate is 1.0-fold (0.01 log units) below it; low and high end bracket the measured number.
By their numbers in this assay, from the lowest: compounds 1, 2 and 3 (each within the scatter of the next).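

In this assay, iodo in place of chloro on an aromatic carbon gives a 1.1-fold higher number from compound 2 to compound 3 (0.03 log units; within the scatter), and iodo in place of hydrogen on the same carbon gives a 1.7-fold higher number from compound 1 to compound 3 (0.22 log units; within the scatter) as the second reading. Compound 3 thus puts a second halogen at this carbon, ortho to a methoxy group and meta to a large group, and neither of its steps leaves the scatter, so hydrogen, chloro and iodo cannot be ranked here in this assay. What compound 2 showed for chloro alone now holds for iodo as well, though no evidence is at hand to account for this flat result.

The compounds shown leave open whether any other kind of group at this carbon would move the number beyond the scatter, such as an amine, a hydroxyl, a carboxylic acid or a longer chain, since only hydrogen, chloro and iodo appear there. They also leave open how much the methoxy group itself contributes, as it stays the same in all three compounds and its replacement by a hydroxyl or an ethoxy group is not among them.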